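Phenethyl in place of an aryl group on the sulfur

The source may report more compounds than this note shows. Statements on the series, on what has been measured and on what is new or still open speak of the compounds shown alone.

Compound 1 `Cc1cc(C)cc(SCc2ccc(C(=O)Nc3ccccc3N)cc2)c1` is the stronger of the two measured compounds here: in a functional assay on HeLa cells (Homo sapiens) for antiproliferative activity, read by CCK-8 assay, with a stated time of 72 h (a higher number here means a weaker inhibitor, a lower number a stronger inhibitor), compound 1 gives 2090 nM, while compound 2 `COC(=O)c1ccccc1SCc1ccc(C(=O)Nc2ccccc2N)cc1` gives 6680 nM. Compound 3 `Nc1ccccc1NC(=O)c1ccc(CSCCc2ccccc2)cc1` has not yet been tested. It differs from compound 1 in one place (phenethyl in place of 3,5-dimethylphenyl on a sulfur). Among the measured compounds shown here, no measured pair shows what such a swap does, so the step is expected to be small, probably a little upward a 1.4-fold higher number from compound 1 to compound 3 (0.16 log units; within the scatter), close to the usual scatter. Compound 3 is therefore estimated at 3000 nM, with a range from 1000 nM to 9000 nM.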

Compound 3, half-maximal inhibitory concentration: 6430 nM
Estimate against measurement, compound 3: 2.1-fold (0.33 log units) below; the measured number falls inside the stated range.
By their numbers in this assay, from the lowest: compound 1; then compounds 3 and 2 (each within the scatter of the next).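

Replacing 3,5-dimethylphenyl with phenethyl on the sulfur keeps the same atoms but joins them differently, and in this assay this alone gives a 3.1-fold higher number from compound 1 to compound 3 (0.49 log units; beyond the scatter). So this position is sensitive to the arrangement of the group, not only to its atom count, and the aromatic ring of phenethyl does not preserve the activity of compound 1. Nothing available explains this loss.

Going by these compounds, it remains open how a benzyl group or a plain phenyl group on the sulfur would compare. The effect of an amine on the ring of phenethyl is also unknown.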